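Aromatic Ring Replaces Neopentyl on the Imidazole Side Chain

This account rests on a few compounds, and the source may have more. Where it says the series, first, only, none or still open, it means among the compounds named here.

Three compounds share one core and differ only in the group that hangs from a saturated chain carbon bound to an aromatic carbon. Compound 1 `O=C(O)c1ccccc1-c1ccc(CCc2ncc(CCC3CCCCC3)[nH]2)cc1` gives 33 nM in an in vitro functional assay on cells for agonist activity at Bombesin receptor subtype-3 (Mus musculus), read by luminescence and calcium flux; on this read-out higher numbers stand for an effect only at larger amounts of compound and lower numbers for an effect already at smaller amounts. Compound 2 `O=C(O)c1ccccc1-c1ccc(CCc2ncc(CC3CC3)[nH]2)cc1` gives 72 nM in this assay, and compound 3 `CC(C)(C)CCc1cnc(CCc2ccc(-c3ccccc3C(=O)O)cc2)[nH]1` gives 6.2 nM. Compound 3 thus stands at the lowest number of the three; the step of a 5.3-fold lower number from compound 1 to compound 3 (0.73 log units; beyond the scatter) and the step of a 12-fold lower number from compound 2 to compound 3 (1.06 log units; beyond the scatter) both lie beyond the scatter, while the step of a 2.2-fold higher number from compound 1 to compound 2 (0.34 log units; beyond the scatter) is modest.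

Compound 4 `COc1ccccc1Cc1cnc(CCc2ccc(-c3ccccc3C(=O)O)cc2)[nH]1` is the next variation: 2-methoxyphenyl in place of neopentyl on a saturated chain carbon bound to an aromatic carbon. Going by the values given here, every measured step so far exchanged one saturated, carbon-only group for another; none introduced an aromatic ring or a hydrogen-bond acceptor at this place, so none bears on the change directly. What the three steps do show is that this position is sensitive, with swings from modest to large, and that compound 3 holds the best number reached. Starting from the best point, the change to a group of a new kind is expected to cost something rather than gain, so a moderate rise in the number, a 3.2-fold higher number from compound 3 to compound 4 (0.51 log units; beyond the scatter), is estimated. Compound 4 is therefore expected to give about 20 nM in this assay, within a range from 5 nM to 80 nM.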

Compound 4, half-maximal effective concentration: 163 nM
Compound 4: middle estimate off by 8.2-fold (0.91 log units), on the low side; the measured number lies above the stated range.
By their numbers in this assay, from the lowest: compound 3; then compound 1; then compound 2; then compound 4.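

In this assay, going by these compounds alone, 2-methoxyphenyl is the first group at this place to bring an aromatic ring and a hydrogen-bond acceptor, and it gives a 26-fold higher number from compound 3 to compound 4 (1.42 log units; beyond the scatter), the largest step seen so far at this position. The loss is not measured only against the best compound, since the same exchange also gives a 2.3-fold higher number from compound 2 to compound 4 (0.35 log units; beyond the scatter) and a 4.9-fold higher number from compound 1 to compound 4 (0.69 log units; beyond the scatter), so that among these four compounds the 2-methoxyphenyl group sits behind all three saturated, carbon-only groups, even though two of those steps are modest in size. Nothing at hand explains why the number rises so far with this change.

The ring and the methoxy group enter together here, so the share of each in the rise cannot be separated, and a plain phenyl group at this place would be the comparison that speaks to this. Going by these compounds, how an amine or a longer saturated chain at this place would read in this assay also remains open, as does whether any group can bring the number below that of compound 3.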